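Cyclopentyl Ether Expected to Track the Isopropyl Gain

The source may hold more compounds than are shown below. What is called first, only, known or untested is meant among the compounds shown, and "the series" means these compounds.

Measured so far in an assay on cells with melanin-concentrating hormone receptor 1 (Homo sapiens) as the target, read by radioligand binding; a higher number here means a weaker inhibitor, a lower number a stronger inhibitor:
compound 1, `CCOCCOc1cccc2ccc(N)nc12`, > 2000 nM
compound 2, `CC#CCCOc1cccc2ccc(N)nc12`, > 2000 nM
compound 3, `CC(C)Oc1cccc2ccc(N)nc12`, 437 nM

Compound 1 stands at a limit of the assay and not at a number, > 2000 nM. Compound 2 likewise gives only a limit, > 2000 nM. Compound 3 gives a real number, 437 nM. Two of the three values therefore sit at the same limit, (the limit of > 2000 nM in this assay, at which 2 of the 3 values shown sit), which leaves a step that the two limits leave unreadable from compound 1 to compound 2. The two readable steps both point the same way: an at least 4.5-fold lower number from compound 1 to compound 3 (0.66 log units; beyond the scatter) and an at least 4.5-fold lower number from compound 2 to compound 3 (0.66 log units; beyond the scatter), each obtained by trading a chain on the aromatic oxygen for isopropyl.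

Compound 4, `Nc1ccc2cccc(OC3CCCC3)c2n1`, is not yet measured. It differs from compound 1 by cyclopentyl in place of 2-ethoxyethyl on an oxygen on an aromatic ring. The change most like it among the measured steps is the move to isopropyl, which gave an at least 4.5-fold lower number from compound 1 to compound 3 (0.66 log units; beyond the scatter). Cyclopentyl, a compact ring, is expected to behave in the same direction, so the expected step is an at least 6.6-fold lower number from compound 1 to compound 4 (0.82 log units; beyond the scatter). Compound 4 is therefore estimated at 300 nM, with a range from 90 nM to 1500 nM.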

Compound 4, half-maximal inhibitory concentration: > 2000 nM
Compound 4 ended at the assay's limit (the forecaster's own chance of this, stated with the estimate: 15%); middle value at least 6.6-fold (0.82 log units) from the limit.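

In this assay, the compact ring does not follow isopropyl on this oxygen on an aromatic ring: the change gives an at least 4.5-fold higher number from compound 3 to compound 4 (0.66 log units; beyond the scatter). Isopropyl in compound 3 is now the only group here that gives a real number, and compound 4 adds what the earlier compounds could not show, that a five-membered ring of carbon only, with no hydrogen-bond acceptor, fares no better than the open chains: the limit of > 2000 nM in this assay, at which 3 of the 4 values shown sit. The steps from compound 1 and from compound 2 to compound 4 cannot be read, as each joins two limits.

On these data alone, whether a cyclopropyl or a tert-butyl group on the same oxygen would match or improve on compound 3 stays open. The limits also leave compound 1, compound 2 and compound 4 unordered among themselves.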